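A few compounds are considered here, and "the series" means these few. Any claim that something is new, unique, unknown or untested is made for them only; others in the source may bear on it.

Compound 1 `Cc1ccc(-c2nnc(-c3ccc(F)c(C(F)(F)F)c3)o2)cc1Nc1nccc(-c2cccnc2)n1`, in a functional assay on K562 cells (Homo sapiens) for inhibition, read by MTT assay, with a stated time of 72 h (on this read-out lower numbers stand for stronger inhibition and higher numbers for weaker inhibition), compound 1 gives 29700 nM.
Compound 2 `Cc1ccc(-c2nnc(-c3ccc(CN4CCN(CCN)CC4)c(C(F)(F)F)c3)o2)cc1Nc1nccc(-c2cccnc2)n1`, in this assay compound 2 gives 300 nM.

Within the data shown here, compound 2 stands lowest of the two measured numbers; its nearest neighbour is compound 1, with the one measured step running a 99-fold lower number from compound 1 to compound 2 (2.00 log units; beyond the scatter). Compound 3 `Cc1ccc(-c2nnc(-c3ccc(CN4CCN(CCN=C=S)CC4)c(C(F)(F)F)c3)o2)cc1Nc1nccc(-c2cccnc2)n1` differs from compound 2 by a group of 3 heavy atoms (1 carbon, 1 nitrogen, 1 sulfur; no ring) in place of one nitrogen atom, on a saturated chain carbon, two bonds along the chain from an amine nitrogen in a ring. Among the measured compounds shown here, no measured step touches this position directly, so the large change from compound 1 to compound 2 offers only a loose guide. A moderate step in this assay is expected, estimated as a 2.7-fold higher number from compound 2 to compound 3 (0.43 log units; beyond the scatter), toward a higher number. Compound 3 is therefore expected to give about 800 nM, with a range from 200 nM to 4000 nM.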

Compound 3, half-maximal inhibitory concentration: 500 nM
Beside the measured number, compound 3's estimate is 1.6-fold (0.20 log units) above it; the measured number falls inside the stated range.
By their numbers in this assay, from the lowest: compounds 2 and 3 (each within the scatter of the next); then compound 1.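

In this assay, putting the group of 3 heavy atoms (1 carbon, 1 nitrogen, 1 sulfur) in place of the amino group gives a 1.7-fold higher number from compound 2 to compound 3 (0.22 log units; within the scatter), so this chain position accepts a group with 0 hydrogen-bond donors in place of one that has a donor. The large gain over the fluoro compound also persists without the amino group, with a 59-fold lower number from compound 1 to compound 3 (1.77 log units; beyond the scatter). Nothing available explains why compound 2 and compound 3 read alike.

Going by these compounds, it remains open whether the ring or the chain carries that gain, and how a hydroxyl group or a longer chain would read at this position.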